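The source may hold more compounds than are shown below. What is called first, only, known or untested is meant among the compounds shown, and "the series" means these compounds.

In a functional assay on A549 cells (Homo sapiens) for inhibition, read by sulforhodamine B assay, with a stated time of 74 h (a lower number here means a stronger inhibitor, a higher number a weaker inhibitor), compound 3 `O=C1C=CC2(C=C1)OCC(=O)N2S(=O)(=O)c1ccc(N2CCCC2=O)cc1` gives 5 nM, the lowest number measured in this small set. Compound 1 `Cc1ccc(S(=O)(=O)N2C(=O)COC23C=CC(=O)C=C3)cc1` gives 110 nM. Compound 2 `O=C1C=CC2(C=C1)OCC(=O)N2S(=O)(=O)c1ccc([N+](=O)[O-])cc1` reads > 10000 nM, which is a limit of the assay and not a number. Compound 4 `O=C1C=CC2(C=C1)OCC(=O)N2S(=O)(=O)c1ccc(C(F)(F)F)cc1` keeps the shared core but has trifluoromethyl in place of 2-oxopyrrolidin-1-yl on an aromatic carbon. The three measured steps all involve this same aromatic carbon. The two that bear most directly are large and both bring in 2-oxopyrrolidin-1-yl: a 22-fold lower number from compound 1 to compound 3 (1.34 log units; beyond the scatter) and an at least 2000-fold lower number from compound 2 to compound 3 (3.30 log units; beyond the scatter). The third, with nitro in place of methyl, is also large: an at least 90-fold higher number from compound 1 to compound 2 (1.95 log units; beyond the scatter). The outcome at this carbon therefore varies widely, and neither replacement of 2-oxopyrrolidin-1-yl measured so far comes close to compound 3. On these steps, a large move to a higher number is expected in this assay, though its size remains uncertain. The expected step is a 140-fold higher number from compound 3 to compound 4 (2.15 log units; beyond the scatter). The estimated value for compound 4 is 700 nM, with an expected range of 80 nM to 8000 nM.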

Compound 4, half-maximal inhibitory concentration: > 10000 nM
Compound 4 was reported as a limit; the forecaster's own chance of this, stated with the estimate: 15%; at least 14-fold (1.15 log units) between middle value and limit.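

In this assay compound 4 reads > 10000 nM, which is a limit of the assay and not a number. Trifluoromethyl therefore falls with nitro rather than with methyl or 2-oxopyrrolidin-1-yl on this aromatic carbon, giving an at least 2000-fold higher number from compound 3 to compound 4 (3.30 log units; beyond the scatter) and an at least 90-fold higher number from compound 1 to compound 4 (1.95 log units; beyond the scatter), so a second replacement now loses the low number of compound 3 and also that of compound 1. The step from compound 2 to compound 4 cannot be read, because both compounds sit at the same limit: the limit of > 10000 nM in this assay, at which 2 of the 4 values shown sit.

The compounds shown leave open how far below that limit trifluoromethyl and nitro each lie. They also leave open whether an open-chain acetamido group, an amine or a morpholine on this carbon would give a number as low as that of compound 3.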